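The compounds below may be only part of what the source reports. "The series", "measured", "known", "first", "only" and "open" are said of these compounds alone.

Measured so far in a functional assay on MDA-MB-231 cells (Homo sapiens) for antiproliferative activity, read by sulforhodamine B assay; a lower number here means a stronger inhibitor of growth, a higher number a weaker inhibitor of growth:
Compound 1, `Cc1cc(C)c2sc(NC(=O)c3ccc([N+](=O)[O-])cc3)nc2c1`: compound 1 gives 0.29 ug/mL.
Compound 2, `Cc1cc(C)c2sc(NC(=O)c3ccc(C(F)(F)F)cc3)nc2c1`: compound 2 gives 0.45 ug/mL.
Compound 3, `COc1ccc2sc(NC(=O)c3ccc([N+](=O)[O-])cc3)nc2c1`: for compound 3 the reading is a limit of the assay, > 10 ug/mL, not a number.

Compound 1 and compound 2 share one core and differ in a single place: trifluoromethyl in place of nitro on an aromatic carbon. This change moved the reading by a 1.6-fold higher number from compound 1 to compound 2 (0.19 log units; within the scatter), so the two compounds cannot be told apart in this assay. Compound 3 carries a different core; how the core of compound 3 differs from that of compound 1 is not broken down here. What is known of compound 3 is only that it sits at the limit of > 10 ug/mL in this assay, at which 1 of the 3 values shown sits.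

Compound 4, `COc1ccc2sc(NC(=O)c3ccc(C(F)(F)F)cc3)nc2c1`, is not yet measured. It stands to compound 3 as compound 2 stands to compound 1: trifluoromethyl in place of nitro on an aromatic carbon. Within the data shown here, the change is the same kind, at the same kind of place, as the one between compound 1 and compound 2.

Since the same change left the reading of compound 1 and compound 2 within the scatter, compound 4 is expected to stay close to where compound 3 sits, and the most likely outcome is again a limit rather than a number. The expected step is a step that the limit leaves unreadable from compound 3 to compound 4, and compound 4 is estimated at 15 ug/mL, with a range from 5 ug/mL to 50 ug/mL. This rests on compound 3 at > 10 ug/mL and on the step of a 1.6-fold higher number from compound 1 to compound 2 (0.19 log units; within the scatter).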

Compound 4, concentration for 50% growth inhibition: > 10 ug/mL
Compound 4 was reported as a limit (the forecaster's own chance of this, stated with the estimate: 75%); the middle value is on the limit's open side.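

In this assay compound 4 gives > 10 ug/mL, which is a limit of the assay and not a number. Among these compounds, compound 3 also stands at a limit, so no step between compound 3 and compound 4 can be read: the limit of > 10 ug/mL in this assay, at which 2 of the 4 values shown sit. The compounds shown leave open how far either compound lies past that limit, and whether trifluoromethyl in place of nitro matters on the core of compound 3.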